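Swapping the aryl group of a sulfonamide on a shared coumarin-like core

The compounds below may be only part of what the source reports. "The series", "measured", "known", "first", "only" and "open" are said of these compounds alone.

Of the compounds shown here, three sharing one core have been tested in a functional assay on CFPAC-1 cells (Homo sapiens) for inhibition, read by MTT assay, with a stated time of 72 h; on this read-out higher numbers stand for weaker inhibition and lower numbers for stronger inhibition. Compound 1 `O=c1cc(Cn2cc(-c3ccc(Br)cc3)nn2)c2ccc(O)cc2o1` gives 52900 nM. Compound 2 `CCCCc1ccc(-c2cn(Cc3cc(=O)oc4cc(O)ccc34)nn2)cc1` gives 69800 nM, and the step of a 1.3-fold higher number from compound 1 to compound 2 (0.12 log units; within the scatter) shows that this change made no difference that can be trusted. Compound 3 `Cc1ccc(S(=O)(=O)NCc2cn(Cc3cc(=O)oc4cc(O)ccc34)nn2)cc1` carries a sulfonamide arm instead and gives 68900 nM; its number sits between those of the other two, and its gaps to both compound 2 and compound 1 are within the scatter, so all three compounds are, on these numbers, indistinguishable.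

Compound 4 `O=c1cc(Cn2cc(CNS(=O)(=O)c3ccc(F)cc3Cl)nn2)c2ccc(O)cc2o1` is the next compound in this series and has not yet been measured. The change from compound 3 is 2-chloro-4-fluorophenyl in place of 4-methylphenyl on a sulfonyl sulfur. Going by the values given here, no measured step touches this part of the molecule: the single step between measured compounds concerns a substituent on a different aromatic ring, and even that step stayed within the scatter. The measured compounds therefore give no reason to expect anything other than a number close to that of compound 3, and the estimated step of a 1.1-fold lower number from compound 3 to compound 4 (0.05 log units; within the scatter) is expected to stay within the scatter. For compound 4 the expected value in this assay is 62000 nM, with a likely range from 25000 nM to 150000 nM.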

Compound 4, half-maximal inhibitory concentration: > 100000 nM
Compound 4: only a limit was reported (the forecaster's own chance of this, stated with the estimate: 10%); middle value at least 1.6-fold (0.20 log units) from the limit.
By their numbers in this assay, from the lowest: compounds 1, 3 and 2 (each within the scatter of the next). At a limit, above all of these: compound 4.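

Going by these compounds alone, this is the first look at the aryl group on the sulfonyl sulfur, and exchanging 4-methylphenyl for 2-chloro-4-fluorophenyl in this assay gives an at least 1.4-fold higher number from compound 3 to compound 4 (0.16 log units; that floor lies within the scatter). The reading for compound 4 is a limit and not a number: the limit of > 100000 nM in this assay, at which 1 of the 4 values shown sits. The new group therefore brought compound 4 no measurable gain over compound 3, but the floor of the step is too small to count as a real loss, and how far the true value of compound 4 lies beyond the limit cannot be read from these data.

The chlorine and the fluorine enter together in a single change, so the compounds shown cannot tell whether either atom alone would give the same result, or whether this position affects the read-out at all. From the compounds shown here alone, it also remains open whether a different kind of group on the sulfonyl sulfur, such as an amine, a carboxylic acid or a longer alkyl chain in place of the aryl ring, would bring the number clearly away from those of the other compounds.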